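The source may report more compounds than this note shows. Statements on the series, on what has been measured and on what is new or still open speak of the compounds shown alone.

Measured in a functional assay on U-251 cells (Homo sapiens) for inhibition, read by sulforhodamine B assay, with a stated time of 48 h; a higher number here means a weaker inhibitor of growth, a lower number a stronger inhibitor of growth:
- Compound 1 `CCOC(=O)c1nn(-c2ccc(Cl)cc2)c(-c2ccc(Br)cc2)c1CNC(C)(C)C`: > 511000 nM; > 476000 nM (2 entries)
- Compound 2 `CC(C)(C)NCc1c(C(=O)O)nn(-c2ccccc2)c1-c1ccc(Br)cc1`: 126000 nM
- Compound 3 `CC(C)(C)NCc1c(C(=O)O)nn(-c2ccc(Cl)cc2)c1-c1ccc(Cl)cc1`: 518000 nM

The entries for compound 1 are limits of the assay, not numbers. Of the two true numbers, compound 3 has the higher, and compound 2 lies lower by more than the scatter. Compound 4 `CC(C)(C)NCc1c(C(=O)O)nn(-c2ccc(Cl)cc2)c1-c1ccc(Br)cc1` has bromo in place of chloro on an aromatic carbon of compound 3 (bromo in place of chloro on an aromatic carbon). Within the data shown here, no measured pair isolates this change, so only a small shift is expected in this assay, toward a lower number and within the scatter. The expected step is a 1.7-fold lower number from compound 3 to compound 4 (0.24 log units; within the scatter). For compound 4, the estimated value is 300000 nM, with an expected range of 120000 nM to 700000 nM.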

Compound 4, concentration for 50% growth inhibition: > 542000 nM
Compound 4 was reported as a limit (the forecaster's own chance of this, stated with the estimate: 25%); middle value at least 1.8-fold (0.25 log units) from the limit.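

Compound 4 gives no number, only a limit of the assay: the limit of > 542000 nM in this assay, at which 1 of the 4 values shown sits. In this assay, the change from 4-chlorophenyl to 4-bromophenyl gives an at least 1.0-fold higher number from compound 3 to compound 4 (0.01 log units; that floor lies within the scatter), so no shift can be claimed for it. Chloro in place of hydrogen on an aromatic carbon gives an at least 4.3-fold higher number from compound 2 to compound 4 (0.63 log units; beyond the scatter), the only new step here that clears the scatter, toward weaker growth inhibition.

On these data alone, how far compound 4 lies past its limit stays open, and so does the true size of both steps. The compounds shown also leave open how fluoro or methoxy at this place would read, or an amide in place of the carboxylic acid.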